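A few compounds are considered here, and "the series" means these few. Any claim that something is new, unique, unknown or untested is made for them only; others in the source may bear on it.

Of the compounds shown here, three have so far been measured in a physicochemical assay for acid dissociation. Compound 1 `Fc1ccc(-c2ccc3c(NCCCNCc4ccco4)ccnc3c2)cc1` gives 9.47. Compound 2 `COc1cccc(CNCCCNc2ccnc3cc(Oc4ccc(F)cc4)ccc23)c1O` gives 9.28, and compound 3 `COc1ccc(F)cc1CNCCCNc1ccnc2cc(CCc3ccccc3)ccc12` gives 9.47. On these numbers compound 1 stands level with compound 3 at the digits shown, and its gap to compound 2 lies within the scatter of repeated measurements, so the three numbers cannot be told apart from one another in this assay.

The next compound, compound 4 `COc1ccc(Oc2ccc3c(NCCCNCc4ccco4)ccnc3c2)cc1`, has not yet been measured. It differs from compound 1 in one place: 4-methoxyphenoxy in place of 4-fluorophenyl on an aromatic carbon. Within the data shown here, no two of the measured compounds differ in just one place, so there is no measured step of this kind to lean on. What the three measured compounds do show is that the groups varying among them leave the numbers in this assay together within the scatter. The step from compound 1 to compound 4 is therefore expected to be none beyond the scatter, a number 0.02 log units lower from compound 1 to compound 4 (within the scatter). Compound 4 is expected to give 9.45, within a range from 9.15 to 9.75.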

Compound 4, acid dissociation constant: 9.28
Estimate against measurement, compound 4: 0.17 log units above, within the range that was stated.
By their numbers in this assay, from the lowest: compounds 2, 4, 1 and 3 (each within the scatter of the next).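

Among these compounds, this is the first measured step at this position on the shared core. In this assay, replacing 4-fluorophenyl with 4-methoxyphenoxy on this aromatic carbon gives a number 0.19 log units lower from compound 1 to compound 4 (within the scatter), so exchanging a group of 7 heavy atoms and 0 hydrogen-bond acceptors for one of 9 heavy atoms and 2 hydrogen-bond acceptors does not move the number beyond the scatter. Nothing measured here offers an explanation for this result.

This is a single step between two groups that both carry a six-membered aromatic ring of carbon only, so it cannot show how far the position tolerates change in general. Going by these compounds, whether an amine or a carboxylic acid on the same carbon would leave the number within the scatter remains open.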